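Piperidine nitrogen substituent swapped: sulfonyl aryl to direct aryl

The source may hold more compounds than are shown below. What is called first, only, known or untested is meant among the compounds shown, and "the series" means these compounds.

Three compounds have been measured in an assay on isolated protein for displacement of a labelled ligand from secreted frizzled-related protein 1 (Homo sapiens), read by fluorescence polarization, with a stated time of 30 min; a lower number here means a stronger inhibitor, a higher number a weaker inhibitor:

compound 1, `O=C(c1ccc(Cl)cc1)N1CCC(NS(=O)(=O)c2cc(S(=O)(=O)c3ccccc3)ccc2C(F)(F)F)CC1`, gives 300 nM
compound 2, `CN(C)c1ccc(C(=O)N2CCC(NS(=O)(=O)c3cc(S(=O)(=O)c4ccccc4)ccc3C(F)(F)F)CC2)cn1`, gives 40 nM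
compound 3, `O=C(O)c1cccc(S(=O)(=O)N2CCC(NS(=O)(=O)c3cc(S(=O)(=O)c4ccccc4)ccc3C(F)(F)F)CC2)c1`, gives 20 nM

Compound 3 has the lowest number of the three. Its nearest neighbour is compound 2, and the gap a 2.0-fold lower number from compound 2 to compound 3 (0.30 log units; within the scatter) lies within the scatter, so no order between them can be claimed. Compound 1 lies furthest away, with a 15-fold lower number from compound 1 to compound 3 (1.18 log units; beyond the scatter) being beyond the scatter.

Compound 4, `O=C(O)c1ccc(N2CCC(NS(=O)(=O)c3cc(S(=O)(=O)c4ccccc4)ccc3C(F)(F)F)CC2)cc1`, has not yet been measured in this assay. Going by the values given here, it differs from compound 3 at the same ring nitrogen that the earlier steps varied: 4-carboxyphenyl in place of (3-carboxyphenyl)sulfonyl on an amine nitrogen in a ring. The two steps that bear on this position are a 15-fold lower number from compound 1 to compound 3 (1.18 log units; beyond the scatter), a large change, and a 2.0-fold lower number from compound 2 to compound 3 (0.30 log units; within the scatter), within the scatter. Among the compounds with values here, neither step removes a sulfonyl link and attaches the aryl ring directly, so the data give no direct precedent. Because the carboxyphenyl group is retained and because a 2.0-fold lower number from compound 2 to compound 3 (0.30 log units; within the scatter) shows this position tolerating varied groups, compound 4 is expected to stay near compound 3, with at most a modest rise, giving an expected 3.0-fold higher number from compound 3 to compound 4 (0.48 log units; beyond the scatter). The estimate for compound 4 is 60 nM, ranging from 15 nM to 250 nM.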

Compound 4, half-maximal inhibitory concentration: 120 nM
For compound 4 the middle estimate is 2.0-fold (0.30 log units) below the measured one, and the stated range covers the measured number.
By their numbers in this assay, from the lowest: compounds 3 and 2 (each within the scatter of the next); then compound 4; then compound 1.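

In this assay, going by these compounds alone, this position proves less forgiving than the earlier compounds suggested: with the sulfonyl link gone and the aryl ring set directly on the ring nitrogen, the numbers show a 6.0-fold higher number from compound 3 to compound 4 (0.78 log units; beyond the scatter) and a 3.0-fold higher number from compound 2 to compound 4 (0.48 log units; beyond the scatter), while a 2.5-fold lower number from compound 1 to compound 4 (0.40 log units; beyond the scatter) keeps the new group ahead of the (4-chlorophenyl)carbonyl group. A carboxyphenyl group alone therefore does not hold the number at the level of compound 3. Within the data shown here, the single change both removes the sulfonyl link and replaces 3-carboxyphenyl with 4-carboxyphenyl, and no information available here accounts for the shift.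

The compounds shown leave open which of those two differences matters, a question that 3-carboxyphenyl set directly on the nitrogen or (4-carboxyphenyl)sulfonyl could address. They also leave open whether a carboxylic acid is needed at all, since a methyl ester or a primary amide on the same ring is not among them.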